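Saccharin-type benzyl amides: cytotoxicity notes toward compound 3

The compounds below may be only part of what the source reports. "The series", "measured", "known", "first", "only" and "open" are said of these compounds alone.

Compound 1 (`CC(C)(C)OC(=O)c1ccc(CN2C(=O)c3ccccc3S2(=O)=O)cc1`) carries a tert-butyl ester on the shared core. In an ADME assay on RAW264.7 cells (Mus musculus) for cytotoxicity, read by WST assay (on this read-out lower numbers stand for higher toxicity in this test and higher numbers for lower toxicity in this test), compound 1 gives > 100000 nM, which is a limit of the assay and not a number. Compound 2 (`CN(C(=O)OC(C)(C)C)C(=O)c1ccc(CN2C(=O)c3ccccc3S2(=O)=O)cc1`) replaces the tert-butoxy on the carbonyl carbon with methyl(tert-butoxycarbonyl)amino. In this assay compound 2 gives > 100000 nM, again a limit rather than a number. The step that the two limits leave unreadable from compound 1 to compound 2 is therefore unreadable, as both values sit at the limit of > 100000 nM in this assay, at which 2 of the 2 values shown sit. Compound 2 thus stands only at a limit, with no number to anchor it.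

Compound 3 (`CN(Cc1ccco1)C(=O)c1ccc(CN2C(=O)c3ccccc3S2(=O)=O)cc1`) differs from compound 2 by (furan-2-yl)methyl in place of tert-butoxycarbonyl on an amide-type nitrogen. Among the measured compounds shown here, the only measured step is unreadable, so it gives no size in either direction for this change. The expectation is a step of a number no higher from compound 2 to compound 3 (the limit leaves the size open) of no size beyond the scatter. Compound 3 is thus expected to give about 100000 nM in this assay, within 30000 nM to 300000 nM, most likely again reported as a limit.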

Compound 3, concentration lethal to 50% of the cells: > 100000 nM
Compound 3: only a limit was reported; the forecaster's own chance of this, stated with the estimate: 70%; the middle value lies on the limit itself.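

No step among compound 1, compound 2 and compound 3 can be read in this assay, as all three values are limits and not numbers: the limit of > 100000 nM in this assay, at which 3 of the 3 values shown sit.

The compounds shown leave open what size any of these changes has in this assay, and whether any change on the shared core would give a reading inside the range of the assay.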